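The compounds below may be only part of what the source reports. "The series", "measured", "known", "first", "only" and "open" are said of these compounds alone.

In an assay on isolated protein for inhibition of DNA topoisomerase 1 (Homo sapiens), with a stated time of 30 min, tested at 100 uM (a lower number here means less inhibition, a higher number more inhibition at the concentration tested (going by the name of the read-out)), compound 1 `Oc1ccc(-c2cc(-c3ccccc3O)cc(-c3cccc(O)c3)n2)cc1` gives 0%, compound 2 `Oc1ccc(-c2cc(-c3cccc(O)c3)cc(-c3cccc(O)c3)n2)cc1` gives 0%, and compound 3 `Oc1ccc(-c2cc(-c3ccccc3O)nc(-c3ccccc3O)c2)cc1` gives 3.7%; these three values lie within the usual scatter of one another, so none stands apart. Compound 4 `Oc1ccc(-c2cc(-c3cccc(O)c3)nc(-c3ccccc3O)c2)cc1` has not yet been measured in this assay. From compound 1 to compound 2 the change is 3-hydroxyphenyl in place of 2-hydroxyphenyl on an aromatic carbon, and the step was no change at the digits printed from compound 1 to compound 2 (within the scatter). Compound 4 arises from compound 3 by the same kind of change, (3-hydroxyphenyl in place of 2-hydroxyphenyl on an aromatic carbon); here the changed carbon is next to the ring nitrogen, whereas in compound 1 it is opposite the ring nitrogen. The difference between the core of compound 1 and the core of compound 3 is not broken down here. Because the step of no change at the digits printed from compound 1 to compound 2 (within the scatter) was flat, a similarly flat step a number 1.7 percentage points lower from compound 3 to compound 4 (within the scatter) is expected. Compound 4 is therefore estimated to give 2% in this assay, with a likely range from 0% to 12%.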

Compound 4, a percentage reported as inhibition, at one concentration (the size of the read-out at that concentration, not a potency): 1.5%
The estimate for compound 4 lay 0.5 percentage points above the measured number; the measured number falls inside the stated range.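

In this assay, placing 3-hydroxyphenyl where 2-hydroxyphenyl stood on the core of compound 3 gives a number 2.2 percentage points lower from compound 3 to compound 4 (within the scatter). The same change is therefore flat on both cores, and the two steps agree: the same change on two cores in this assay, no change at the digits printed (within the scatter) from compound 1 to compound 2 and a number 2.2 percentage points lower (within the scatter) from compound 3 to compound 4, 2.2 percentage points apart, within the scatter of two such steps All four compounds show little inhibition at the one concentration tested, so this does not show how the change would behave on a core that inhibits strongly.

The compounds shown carry only hydroxyphenyl groups, so it remains open whether an aminophenyl group or a carboxylic acid in one of these places would raise the inhibition in this assay. From the compounds shown here alone, it also remains open what replacing the 4-hydroxyphenyl group would do.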